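The source may report more compounds than this note shows. Statements on the series, on what has been measured and on what is new or still open speak of the compounds shown alone.

Compound 1 `O=Cc1cn(Cc2cccc(C(F)(F)F)c2)c2ccccc12` – 140 nM
Compound 2 `OCc1cn(Cc2ccc(Cl)cc2)c2ccccc12` – 16 nM

Both compounds were tested in a functional assay on NCI-H460 cells (Homo sapiens) for cytotoxicity, read by sulforhodamine B assay, with a stated time of 3 days; on this read-out higher numbers stand for weaker inhibition and lower numbers for stronger inhibition. On these numbers, compound 2 stands lowest at 16 nM, and the higher number of compound 1 , 140 nM, lies beyond the scatter of repeated measurements. The two compounds differ in more than one place, so this gap cannot be tied to any single change.

Compound 3 `OCc1cn(Cc2ccc(Br)cc2)c2ccccc12` has not yet been measured. It keeps the structure of compound 2 except for one swap: bromo in place of chloro on an aromatic carbon, para to a large group (bromo in place of chloro on an aromatic carbon). Within the data shown here, no measured pair here differs in only one place, so the data offer no direct guide to this swap. With one halogen exchanged for another and the rest unchanged, no shift beyond the scatter is expected in either direction. The expected change is small, and the estimated step is a 1.1-fold lower number from compound 2 to compound 3 (0.03 log units; within the scatter). The estimated value for compound 3 is 15 nM, with an expected range from 6 nM to 40 nM.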

Compound 3, half-maximal inhibitory concentration: 31 nM
The estimate for compound 3 lay 2.1-fold (0.32 log units) below the measured number, and the stated range covers the measured number.
By their numbers in this assay, from the lowest: compounds 2 and 3 (each within the scatter of the next); then compound 1.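

Among these compounds, this is the first pair here that differs in one place only, and in this assay it gives a 1.9-fold higher number from compound 2 to compound 3 (0.29 log units; within the scatter). On this aromatic carbon, para to a large group, the two halogens therefore cannot be told apart by these numbers, and the bromo of compound 3 is accommodated as well as the chloro of compound 2 within the scatter of repeated measurements. Nothing available here explains this result or shows what either halogen does at this position.

Going by these compounds, with only these two halogens at this place, it stays open how the read-out would respond to a group of another kind there, such as a methoxy group, an amine or a carboxylic acid. The gap to compound 1 also cannot be assigned to one feature, since compound 1 differs from both compound 2 and compound 3 in more than one place.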